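Ethyl in Place of Fluoro on the Shared Core

A few compounds are considered here, and "the series" means these few. Any claim that something is new, unique, unknown or untested is made for them only; others in the source may bear on it.

Of the compounds shown here, three of the shared core have been measured in an assay on CHO-TREX cells for antagonist activity at transient receptor potential cation channel subfamily A member 1 (Homo sapiens), read by FLIPR and calcium flux, with a stated time of 10 min; a lower number here means a stronger inhibitor, a higher number a weaker inhibitor. Compound 1 `Clc1ccccc1-c1ccc2[nH]ncc2c1` gives 1230 nM in this assay. Compound 3 `Fc1ccccc1-c1ccc2[nH]ncc2c1` gives 3950 nM in this assay, the highest of the two numbers; its nearest neighbour is compound 1, reached by the step of a 3.2-fold higher number from compound 1 to compound 3 (0.51 log units; beyond the scatter). Compound 2 `c1ccc(-c2ccc3[nH]ncc3c2)cc1` gives only a limit of this assay, > 30000 nM. Compound 4 `CCc1ccccc1-c1ccc2[nH]ncc2c1` has not yet been measured; it differs from compound 3 by ethyl in place of fluoro on an aromatic carbon.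

For the measured compounds named here, three measured steps bear on this change: an at least 24-fold higher number from compound 1 to compound 2 (1.38 log units; beyond the scatter), an at least 7.5-fold lower number from compound 2 to compound 3 (0.88 log units; beyond the scatter) and a 3.2-fold higher number from compound 1 to compound 3 (0.51 log units; beyond the scatter). Each shows that the group at this carbon moves the number well beyond the scatter, the chloro compound giving the lowest number and the unsubstituted compound only a limit. An ethyl group has not been tried on this core, so the direction rests on these three points alone. The step for compound 4 is expected to be a 2.6-fold lower number from compound 3 to compound 4 (0.42 log units; beyond the scatter). Compound 4 is therefore estimated at 1500 nM, with a range from 400 nM to 6000 nM.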

Compound 4, half-maximal inhibitory concentration: 584 nM
The estimate for compound 4 lay 2.6-fold (0.41 log units) above the measured number; the range from low to high includes it.
By their numbers in this assay, from the lowest: compound 4; then compound 1; then compound 3. At a limit, above all of these: compound 2.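

In this assay, the ethyl group gives the lowest number of the four compounds, with a 6.8-fold lower number from compound 3 to compound 4 (0.83 log units; beyond the scatter) and a 2.1-fold lower number from compound 1 to compound 4 (0.32 log units; beyond the scatter), so a low number at this carbon does not require a halogen, and chloro is not the best group shown. Relative to hydrogen, ethyl gives an at least 51-fold lower number from compound 2 to compound 4 (1.71 log units; beyond the scatter), a step that extends the range seen at this carbon. That step is anchored by compound 2, whose value is only a limit of the assay: the limit of > 30000 nM in this assay, at which 1 of the 4 values shown sits.

The compounds shown leave open whether a longer chain such as propyl, a branched isopropyl group, or a methoxy group or an amine at this carbon would lower the number further or raise it. They also leave open whether the order seen here holds on any core other than the shared one.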